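This account rests on a few compounds, and the source may have more. Where it says the series, first, only, none or still open, it means among the compounds named here.

Working notes on the series. Compound 1 `Cc1ccc(CN2CCC(C(=O)Nc3ccc(CNc4nc(N(C)C)nc5cc(C)ccc45)cc3)CC2)cc1` carries 4-methylphenyl on a saturated chain carbon bound to an amine nitrogen in a ring; in a functional assay on SV5A8 cells (Homo sapiens) for cytotoxicity (a higher number here means a weaker inhibitor, a lower number a stronger inhibitor), compound 1 gives > 4150 nM, which is a limit of the assay. Compound 2 `CCCCN1CCC(C(=O)Nc2ccc(CNc3nc(N(C)C)nc4cc(C)ccc34)cc2)CC1` carries propyl at that carbon; in this assay compound 2 gives > 10500 nM, again a limit. The step that the two limits leave unreadable from compound 1 to compound 2 therefore has no readable size. Compound 3 `Cc1ccc2c(NCc3ccc(NC(=O)C4CCN(Cc5ccccc5)CC4)cc3)nc(N3CCN[C@@H](C)C3)nc2c1` carries 3-methylpiperazin-1-yl on the shared core; in this assay compound 3 gives > 8860 nM, also a limit. Compound 3 thus stands where the other two stand, at a limit, and none of the three can be ordered against another. Among the compounds with values here, the only evidence that bears on any step is the limit of > 10500 nM in this assay, at which 1 of the 3 values shown sits, the limit of > 4150 nM in this assay, at which 1 of the 3 values shown sits, and (the limit of > 8860 nM in this assay, at which 1 of the 3 values shown sits).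

Compound 4 `Cc1ccc2c(NCc3ccc(NC(=O)C4CCN(Cc5ccccc5)CC4)cc3)nc(N3CCNC(CCO)C3)nc2c1` differs from compound 3 by 3-(2-hydroxyethyl)piperazin-1-yl in place of 3-methylpiperazin-1-yl on an aromatic carbon. Within the data shown here, no measured step touches this position, and the single measured step, a step that the two limits leave unreadable from compound 1 to compound 2, is unreadable, so no size can be carried over to it. The expectation for compound 4 in this assay is that it remains near the limit, with a step that the limit leaves unreadable from compound 3 to compound 4 that is not expected to go beyond the scatter. The estimate for compound 4 in this assay is 10000 nM, within 3000 nM to 35000 nM.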

Compound 4, half-maximal inhibitory concentration: > 8420 nM
Compound 4 ended at the assay's limit (the forecaster's own chance of this, stated with the estimate: 80%); the middle value does not contradict the limit.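

In this assay compound 4 gives > 8420 nM, a limit of the assay. Compound 3 also stands at a limit, and the step from compound 3 to compound 4 cannot be read. The compounds shown leave open how any of the four ranks against another, and whether 3-(2-hydroxyethyl)piperazin-1-yl differs from 3-methylpiperazin-1-yl at all in this read-out.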